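Methoxy for methyl on an aromatic carbon

The compounds below may be only part of what the source reports. "The series", "measured", "known", "first", "only" and "open" are said of these compounds alone.

Measured so far in a functional assay on Jurkat cells (Homo sapiens) for antiproliferative activity, read by MTT assay, with a stated time of 72 h; on this read-out higher numbers stand for weaker inhibition and lower numbers for stronger inhibition:
Compound 1 `COc1ccc(-c2c(C(=O)c3cc(OC)c(OC)c(OC)c3)sc3ccccc23)cc1C` gives > 10000 nM as a limit of the assay
Compound 2 `COc1cc(C(=O)c2sc3ccccc3c2Nc2ccccc2)cc(OC)c1OC` gives 1600 nM
Compound 3 `COc1cc(C(=O)c2sc3ccccc3c2Nc2ccc(C)cc2)cc(OC)c1OC` gives 1700 nM

On these numbers, compound 3 stands level with compound 2 (a 1.1-fold higher number from compound 2 to compound 3 (0.03 log units; within the scatter)). Compound 4 `COc1ccc(Nc2c(C(=O)c3cc(OC)c(OC)c(OC)c3)sc3ccccc23)cc1` carries methoxy in place of methyl on an aromatic carbon, para to a large group (methoxy in place of methyl on an aromatic carbon). Among the measured compounds shown here, the one measured step at this place, methyl in place of hydrogen, is that same small step. The larger steps (an at least 6.2-fold lower number from compound 1 to compound 2 (0.79 log units; beyond the scatter)) and (an at least 5.8-fold lower number from compound 1 to compound 3 (0.76 log units; beyond the scatter)) replace the whole 4-methoxy-3-methylphenyl, so they bear on this change only loosely. No step beyond the scatter is therefore expected in this assay here. The estimated step is a 1.2-fold lower number from compound 3 to compound 4 (0.08 log units; within the scatter) and so stays small. Compound 4 is expected at 1400 nM within an estimated range of 400 nM to 4500 nM on this reasoning.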

Compound 4, half-maximal inhibitory concentration: 3500 nM
Estimate against measurement, compound 4: 2.5-fold (0.40 log units) below, and the stated range covers the measured number.
By their numbers in this assay, from the lowest: compounds 2 and 3 (each within the scatter of the next); then compound 4. At a limit, above all of these: compound 1.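

In this assay, methyl in place of hydrogen had left the number level (a 1.1-fold higher number from compound 2 to compound 3 (0.03 log units; within the scatter)), but methoxy at this same aromatic carbon gives steps beyond the scatter: a 2.1-fold higher number from compound 3 to compound 4 (0.31 log units; beyond the scatter), and a 2.2-fold higher number from compound 2 to compound 4 (0.34 log units; beyond the scatter). This place therefore responds to the group it carries, and methoxy gives weaker inhibition here than either methyl or hydrogen. The remaining step, an at least 2.8-fold lower number from compound 1 to compound 4 (0.45 log units; beyond the scatter), rests on a limit for compound 1 and gives only a bound: the limit of > 10000 nM in this assay, at which 1 of the 4 values shown sits.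

From the compounds shown here alone, whether a hydroxyl, an amine or an ethoxy group at this carbon would read like methoxy or like methyl stays open. So does whether this step holds in other cells.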